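A few compounds are considered here, and "the series" means these few. Any claim that something is new, unique, unknown or untested is made for them only; others in the source may bear on it.

Measured compounds:
Compound 1, `COc1cc(N2CCN(C(=O)N[C@@H](C)c3cccc4ccccc34)CC2)ccc1-n1cc(C)nn1`, in an ADME assay on microsomes from liver (Rattus norvegicus) for metabolic stability, read by LC-MS (a lower number here means slower removal, a higher number faster removal of the compound), gives 230 mL.min-1.g-1.
Compound 2, `COc1cc(N2CCN(C(=O)NCc3cccc4ccccc34)CC2)ccc1-c1cnc(C)o1`, gives in this assay 160 mL.min-1.g-1.
Compound 3, `COc1cc(N2CCN(C(=O)N[C@@H](C)c3cccc4ccccc34)C[C@@H]2C)ccc1-c1cnc(C)o1`, gives in this assay 150 mL.min-1.g-1.

On these numbers compound 3 sits alongside compound 2 and compound 1, the gaps to both lying within the scatter of repeated measurements, so none of the three can be set apart from the others. Compound 4, `COc1cc(N2CCN(C(=O)N[C@@H](C)c3cccc4ccccc34)CC2)ccc1-c1cnc(C)o1`, differs from compound 3 in one place: hydrogen in place of methyl on a saturated ring carbon. Going by the values given here, no measured pair in this set shows that change alone, so its size is not known here. Compound 4 is expected to stay close to compound 3, with the step of a 1.2-fold higher number from compound 3 to compound 4 (0.08 log units; within the scatter) in this assay not beyond the scatter. The estimate for compound 4 in this assay is 180 mL.min-1.g-1, in a range from 100 mL.min-1.g-1 to 320 mL.min-1.g-1.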

Compound 4, intrinsic clearance in microsomes: 130 mL.min-1.g-1
Compound 4: middle estimate off by 1.4-fold (0.14 log units), on the high side; the range from low to high includes it.
By their numbers in this assay, from the lowest: compounds 4, 3, 2 and 1 (each within the scatter of the next).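

In this assay hydrogen in place of methyl on the saturated ring carbon gives a step that stays within the scatter (a 1.2-fold lower number from compound 3 to compound 4 (0.06 log units; within the scatter)), so this ring methyl shows no measurable effect on the number. The same holds for the methyl on the saturated chain carbon (a 1.2-fold lower number from compound 2 to compound 4 (0.09 log units; within the scatter)) and for 2-methyl-1,3-oxazol-5-yl in place of 4-methyl-1H-1,2,3-triazol-1-yl on an aromatic carbon (a 1.8-fold lower number from compound 1 to compound 4 (0.25 log units; within the scatter)). No measurement shown here accounts for these steps. From the compounds shown here alone, whether an ethyl, a hydroxymethyl or an amine on that ring carbon would move the number beyond the scatter stays open.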